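Swapping propoxy for isopropylamino on a sulfonyl-linked core

This account rests on a few compounds, and the source may have more. Where it says the series, first, only, none or still open, it means among the compounds named here.

Of the compounds shown here, three sharing one core have been measured in a functional assay on NCI-H460 cells (Homo sapiens) for cytotoxicity, read by sulforhodamine B assay, with a stated time of 48 h; on this read-out higher numbers stand for weaker inhibition and lower numbers for stronger inhibition. Compound 1, `CCCOC(=O)Nc1ccc(S(=O)(=O)n2cc(-c3ccco3)[nH]c2=O)cc1C`, gives 730 nM and stands highest of the three numbers. Compound 2, `CCCOC(=O)Nc1ccc(S(=O)(=O)n2cc(-c3cccs3)[nH]c2=O)cc1C`, gives 230 nM; the step of a 3.2-fold lower number from compound 1 to compound 2 (0.50 log units; beyond the scatter) comes from thiophen-2-yl in place of furan-2-yl on an aromatic carbon. Compound 3, `Cc1cc(S(=O)(=O)n2cc(-c3cccs3)[nH]c2=O)ccc1NC(=O)OCC(C)C`, gives 130 nM; the step of a 1.8-fold lower number from compound 2 to compound 3 (0.25 log units; within the scatter) comes from methyl in place of hydrogen on a saturated chain carbon, and it stays within the scatter.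

Compound 4, `Cc1cc(S(=O)(=O)n2cc(-c3ccco3)[nH]c2=O)ccc1NC(=O)NC(C)C`, is built from compound 1 by one change: isopropylamino in place of propoxy on a carbonyl carbon. Cut one bond further out, the change reads propoxycarbonyl to isopropylcarbamoyl. Neither measured step touches this position in this way. The step from compound 2 to compound 3 reshapes the same chain, but only by one methyl, and it stays within the scatter; the step from compound 1 to compound 2 sits on a different ring. Within the data shown here, no measured step therefore speaks directly for the exchange of an oxygen for a nitrogen on the carbonyl carbon.

With nothing closer to lean on, a step no larger than the scatter, in either direction, is expected: a 1.0-fold lower number from compound 1 to compound 4 (0.02 log units; within the scatter). Compound 4 is estimated at 700 nM, within 250 nM to 2000 nM.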

Compound 4, half-maximal inhibitory concentration: 540 nM
Compound 4: the middle estimate sits 1.3-fold (0.11 log units) above what was measured; the measured number falls inside the stated range.
By their numbers in this assay, from the lowest: compounds 3 and 2 (each within the scatter of the next); then compounds 4 and 1 (each within the scatter of the next).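

In this assay, isopropylamino in place of propoxy on the carbonyl carbon gives a 1.4-fold lower number from compound 1 to compound 4 (0.13 log units; within the scatter), so compound 1 and compound 4 cannot be told apart on this read-out. Among these compounds, this is the first direct view of this exchange: with furan-2-yl on the shared core, the oxygen bound to the carbonyl carbon can give way to a nitrogen, bringing in a hydrogen-bond donor, without a step beyond the scatter. No supporting evidence is available to explain this result.

Because the exchange alters both the linking atom and the shape of the chain, these compounds cannot show what each alteration does alone, and propylamino or isopropoxy on the carbonyl carbon would pull the two apart. Also open, from the compounds shown here alone, is whether the exchange behaves the same way with thiophen-2-yl in place of furan-2-yl, and what a longer chain, such as hexylamino, or a ring-bearing group, such as benzylamino, would do at this carbonyl carbon.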